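The compounds below may be only part of what the source reports. "The series", "measured", "known", "first", "only" and "open" are said of these compounds alone.

Measured compounds:

Compound 1, `O[C@@H]1[C@@H](OCc2ccccc2)[C@H](O)[C@@H](COCc2ccccc2)O[C@H]1Cc1ccccc1`: 35300 nM
Compound 2, `OC[C@H]1O[C@@H](Cc2ccccc2)[C@H](O)[C@@H](OCc2ccccc2)[C@@H]1O`: "not active" (no number reported)

The study looks at sugar-derived compounds, both measured and yet to be tested. In a functional assay on HL-60 cells (Homo sapiens) for antiproliferative activity, read by MTT assay (a lower number here means a stronger inhibitor, a higher number a weaker inhibitor), compound 1 gives 35300 nM, a weak result. Compound 2 is reported in this assay only as "not active" (no number reported), so no single number marks where it stands; it can be placed no better than at the inactive end, with compound 1 the only measured reference point and itself a weak inhibitor.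

Compound 3, `OC[C@H]1O[C@@H](Cc2ccccc2)[C@H](O)[C@@H](O)[C@@H]1O`, is the unmeasured member. It differs from compound 2 in one place: hydrogen in place of benzyl on an oxygen on a saturated carbon. Since no numbered pair in this set shows what such a change does in this assay, the direction of the step cannot be read from the data. With compound 2 inactive and compound 1 weak, the step is expected to be no more than the scatter, and compound 3 is expected to stay at the weak or inactive end, with a fair chance that the assay again reports no number.

Compound 3 is estimated at 90000 nM in this assay, within 20000 nM to 400000 nM.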

Compound 3, half-maximal inhibitory concentration: "not active" (no number reported)
The entry for compound 3 holds no number, and the estimate cannot be compared.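

In this assay compound 2 and compound 3 are both reported only as not active, so no step can be read from the change of benzyloxy to hydroxy between them. The compounds shown leave open what that change does where a number can be measured. No further data shown bear on this result.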